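This account rests on a few compounds, and the source may have more. Where it says the series, first, only, none or still open, it means among the compounds named here.

Compound 1, `Clc1cccc(-n2ncnc2Nc2ccccc2)c1Cl`, gives 3890 nM in a functional assay for antagonist activity at P2X purinoceptor 7 (Rattus norvegicus), read by FLIPR and calcium flux; on this read-out higher numbers stand for weaker inhibition and lower numbers for stronger inhibition.
Compound 2, `Cc1ccccc1Nc1ncnn1-c1cccc(Cl)c1Cl`, gives 240 nM in this assay.
Compound 3, `CCc1ccccc1Nc1ncnn1-c1cccc(Cl)c1Cl`, gives 288 nM in this assay.

All three share the same core, and they differ only in the small group carried on the ring attached through the amine linker. On the numbers shown, compound 3 stands second highest of three; its nearest neighbour is compound 2, from which it differs only within the usual scatter, while compound 1 sits far from it.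

Compound 4, `COc1ccccc1Nc1ncnn1-c1cccc(Cl)c1Cl`, has not been measured. It differs from compound 3 by methoxy in place of ethyl on an aromatic carbon. Among the measured compounds shown here, two measured steps bear on this change. Adding a small group at this carbon gave the large steps of a 16-fold lower number from compound 1 to compound 2 (1.21 log units; beyond the scatter) and a 14-fold lower number from compound 1 to compound 3 (1.13 log units; beyond the scatter), whereas lengthening that group by one carbon produced only a 1.2-fold higher number from compound 2 to compound 3 (0.08 log units; within the scatter), a change within the scatter. The methoxy group of compound 4 has the same heavy-atom count as the ethyl group it replaces, so the step of a 1.0-fold higher number from compound 3 to compound 4 (0.02 log units; within the scatter) is expected to stay within the scatter. Compound 4 is therefore estimated at 300 nM in this assay, within a range of 100 nM to 1000 nM.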

Compound 4, half-maximal inhibitory concentration: 2040 nM
Estimate against measurement, compound 4: 6.8-fold (0.83 log units) below; measured number outside the range, above it.
By their numbers in this assay, from the lowest: compounds 2 and 3 (each within the scatter of the next); then compounds 4 and 1 (each within the scatter of the next).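

At this carbon, ortho to a large group, the heavy-atom count alone does not set the result in this assay: ethyl and methoxy have the same count, yet methoxy in place of ethyl gives a 7.1-fold higher number from compound 3 to compound 4 (0.85 log units; beyond the scatter) and methoxy in place of methyl gives an 8.5-fold higher number from compound 2 to compound 4 (0.93 log units; beyond the scatter). Methoxy in place of hydrogen gives only a 1.9-fold lower number from compound 1 to compound 4 (0.28 log units; within the scatter), so the gain seen with methyl and ethyl does not extend to methoxy. Methoxy differs from ethyl by carrying an oxygen and a hydrogen-bond acceptor, but nothing measured here accounts for the change in the number.

From the compounds shown here alone, whether the outcome follows the oxygen or something else about methoxy remains open, and a hydroxyl group, an ethoxy group or a chlorine atom at this carbon could help separate these possibilities. The compounds shown also leave open how methoxy would behave on the other carbons of this ring.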